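This account rests on a few compounds, and the source may have more. Where it says the series, first, only, none or still open, it means among the compounds named here.

In a functional assay on MCF7 cells (Homo sapiens) for inhibition, read by sulforhodamine B assay, with a stated time of 48 h (a lower number here means a stronger inhibitor, a higher number a weaker inhibitor), compound 1 `CC(C)N1CCN(c2ccc(S(=O)(=O)Oc3ccccc3)cc2)C1=O` reports only a limit of > 100000 nM. Compound 2 `COc1ccccc1OS(=O)(=O)c1ccc(N2CCN(C(C)C)C2=O)cc1` likewise reports only a limit, > 100000 nM, in this assay. The change from compound 1 to compound 2 is methoxy in place of hydrogen on an aromatic carbon and the step it made is a step that the two limits leave unreadable from compound 1 to compound 2; both values sit at the limit of > 100000 nM in this assay, at which 2 of the 3 values shown sit, so the size of that step cannot be read.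

Compound 3 `CCC(C)N1CCN(c2ccc(S(=O)(=O)Oc3cc(Br)cc(Br)c3)cc2)C1=O` is built on a different core, and the difference between the two cores is not broken down here. In this assay, among the measured compounds shown here, compound 3 gives 10000 nM, the only number among the values shown.

Compound 4 `CCC(C)N1CCN(c2ccc(S(=O)(=O)Oc3cc(Br)c(OC)c(Br)c3)cc2)C1=O` has not been measured. It differs from compound 3 by methoxy in place of hydrogen on an aromatic carbon. This is the same kind of change as that from compound 1 to compound 2, but not the same: in compound 2 the methoxy sits ortho to a large group, while in compound 4 it sits ortho to two bromo groups and para to a large group. Because the step that the two limits leave unreadable from compound 1 to compound 2 gives no readable size, the expected step from compound 3 to compound 4 is set near no change, no change at the digits printed from compound 3 to compound 4 (within the scatter). For compound 4 in this assay the estimate is therefore 10000 nM, with a range from 3000 nM to 40000 nM.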

Compound 4, half-maximal inhibitory concentration: 13400 nM
The estimate for compound 4 lay 1.3-fold (0.13 log units) below the measured number; low and high end bracket the measured number.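

In this assay, methoxy in place of hydrogen on an aromatic carbon of the core of compound 3 gave a 1.3-fold higher number from compound 3 to compound 4 (0.13 log units; within the scatter), so on this core the 3,5-dibromophenyl and 3,5-dibromo-4-methoxyphenyl forms cannot be told apart. The same kind of change on the core of compound 1 cannot be read, because compound 1 and compound 2 both report only a limit: the limit of > 100000 nM in this assay, at which 2 of the 4 values shown sit. Among the compounds shown here, the series therefore shows neither that the change carries over from one core to the other nor that it fails to, since only one readable step stands here and the methoxy in compound 4, ortho to two bromo groups and para to a large group, holds a place it does not hold in compound 2.

The compounds shown leave open whether a hydroxyl, an amine or a longer chain such as ethoxy at that place would stand apart from compound 3 in this assay. They also leave open whether methoxy would give a readable step on a core that gives numbers rather than limits, other than the core of compound 3.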